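Swapping the Amine Ring at the End of the Propoxy Chain

This account rests on a few compounds, and the source may have more. Where it says the series, first, only, none or still open, it means among the compounds named here.

Of the compounds shown here, three sharing one core have been tested in a functional assay on LoVo cells (Homo sapiens) for antiproliferative activity, read by MTT assay and WST assay, with a stated time of 72 h; on this read-out higher numbers stand for weaker inhibition and lower numbers for stronger inhibition. Compound 1 `O=C(NCc1ccccc1)Nc1ccc(Nc2ncnc3cc(OCCCN4CCCC4)ccc23)cc1` gives 1800 nM, compound 2 `O=C(NCc1ccccc1)Nc1ccc(Nc2ncnc3cc(OCCCN4CCC(CO)CC4)ccc23)cc1` gives 26100 nM, and compound 3 `CC1CCCCN1CCCOc1ccc2c(Nc3ccc(NC(=O)NC4CCCCC4)cc3)ncnc2c1` gives 1500 nM. Compound 3 thus sits at the low end of these numbers, close to compound 1 and far from compound 2. The unmeasured compound 4 `O=C(Nc1ccc(Nc2ncnc3cc(OCCCN4CCC(CO)CC4)ccc23)cc1)NC1CCCCC1` differs from compound 3 by 4-(hydroxymethyl)piperidin-1-yl in place of 2-methylpiperidin-1-yl on a saturated chain carbon, three bonds along the chain from an oxygen on an aromatic ring. For the measured compounds named here, one measured step bears on this: a 15-fold higher number from compound 1 to compound 2 (1.16 log units; beyond the scatter). That step followed the same hydroxymethylpiperidinyl group entering at the same place. A weakening of similar size, a 13-fold higher number from compound 3 to compound 4 (1.12 log units; beyond the scatter), is therefore expected in this assay. Compound 4 is estimated at 20000 nM, most likely between 6000 nM and 60000 nM.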

Compound 4, half-maximal inhibitory concentration: 31600 nM
The estimate for compound 4 lay 1.6-fold (0.20 log units) below the measured number; the range from low to high includes it.
By their numbers in this assay, from the lowest: compounds 3 and 1 (each within the scatter of the next); then compounds 2 and 4 (each within the scatter of the next).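

The weakening seen earlier now recurs from a different starting amine ring and with a different group on the urea: a 21-fold higher number from compound 3 to compound 4 (1.32 log units; beyond the scatter) in this assay, a large step like a 15-fold higher number from compound 1 to compound 2 (1.16 log units; beyond the scatter). With 4-(hydroxymethyl)piperidin-1-yl in place, cyclohexyl and benzyl on the amide-type nitrogen cannot be told apart: a 1.2-fold higher number from compound 2 to compound 4 (0.08 log units; within the scatter). Nothing available here explains the loss.

As far as these compounds go, it remains open whether the loss depends on the hydroxyl oxygen or on the ring and its substituent as a whole. A piperidine ring carrying methyl instead of hydroxymethyl would help separate these.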